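Oxygen Out, Carbon In: A Five-Membered Ring Swap

This account rests on a few compounds, and the source may have more. Where it says the series, first, only, none or still open, it means among the compounds named here.

For the measured compounds named here, compound 1 `CC(Oc1ccccc1-c1ccccc1)C1=NCCO1` gives 5890 nM in an assay on CHO cells for displacement of a labelled ligand from Alpha-2C adrenergic receptor (Homo sapiens) (on this read-out higher numbers stand for weaker inhibition and lower numbers for stronger inhibition), the highest of the two numbers so far; its nearest neighbour, compound 2 `CC(Oc1ccccc1-c1ccccc1O)C1=NCCN1`, gives 1620 nM in this assay, a gap beyond the scatter. Going by the values given here, compound 2 differs from compound 1 in more than one place, so no single step links them. Compound 3 `CC(Oc1ccccc1-c1ccccc1)C1=NCCC1` differs from compound 1 by a group of 5 heavy atoms (4 carbon, 1 nitrogen; one five-membered non-aromatic ring with 1 hetero atom) in place of a group of 5 heavy atoms (3 carbon, 1 nitrogen, 1 oxygen; one five-membered non-aromatic ring with 2 hetero atoms), on a saturated chain carbon bound to an oxygen on an aromatic ring and a saturated chain carbon. Among the compounds with values here, with no measured step of this kind to lean on, the change from compound 1 to compound 3 is expected to be a 1.2-fold lower number from compound 1 to compound 3 (0.07 log units; within the scatter), that is, no step beyond the scatter. Compound 3 is thus estimated at 5000 nM in this assay, within 1500 nM to 16000 nM.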

Compound 3, inhibition constant: 5890 nM
Compound 3: middle estimate off by 1.2-fold (0.07 log units), on the low side, and the stated range covers the measured number.
By their numbers in this assay, from the lowest: compound 2; then compounds 1 and 3 (each within the scatter of the next).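

In this assay, at the saturated chain carbon bound to an oxygen on an aromatic ring and a saturated chain carbon, replacing the five-membered non-aromatic ring with 2 hetero atoms by the one with 1 hetero atom gives no change at the digits printed from compound 1 to compound 3 (within the scatter) on the shared core. For the compounds shown here, this is the first single-place step at this position, and it shows that this read-out does not separate the two rings, even though the entering ring has one hydrogen-bond acceptor fewer. No measurement on hand explains this result. From the compounds shown here alone, whether an open-chain amine or a six-membered ring with two nitrogens at this carbon would move the number remains open.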